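Benzyl in place of an ester side chain on the shared core

The compounds below may be only part of what the source reports. "The series", "measured", "known", "first", "only" and "open" are said of these compounds alone.

In a functional assay on HL-60 cells (Homo sapiens) for cytotoxicity, read by MTT assay, with a stated time of 24 h (on this read-out lower numbers stand for stronger inhibition and higher numbers for weaker inhibition), compound 1 `CN1CCN(CCCCCOc2c(Br)cc(Br)cc2Oc2ccc(Br)cc2Br)CC1` gives 48.3 ug/mL, compound 2 `CC(C)(C)OC(=O)N1CCN(CCCCCOc2c(Br)cc(Br)cc2Oc2ccc(Br)cc2Br)CC1` gives 32.1 ug/mL and compound 3 `CCOC(=O)C(C)Oc1c(Br)cc(Br)cc1Oc1ccc(Br)cc1Br` gives 35.7 ug/mL. Compound 3 lies within the scatter of both others, so the three do not separate. Compound 4 `Brc1ccc(Oc2cc(Br)cc(Br)c2OCc2ccccc2)c(Br)c1` differs from compound 3 as follows: benzyl in place of 1-(ethoxycarbonyl)ethyl on an oxygen on an aromatic ring. Going by the values given here, the only measured step, a 1.5-fold lower number from compound 1 to compound 2 (0.18 log units; within the scatter), stays within the scatter, but it concerns an amine nitrogen in a ring and does not test this exchange on oxygen. The data therefore give no reason to expect a change beyond the scatter. The expected step is a 1.0-fold lower number from compound 3 to compound 4 (0.01 log units; within the scatter). For compound 4 the estimate is 35 ug/mL, with an expected range from 16 ug/mL to 75 ug/mL.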

Compound 4, half-maximal inhibitory concentration: 27.9 ug/mL
Estimate against measurement, compound 4: 1.3-fold (0.10 log units) above, and the stated range covers the measured number.
By their numbers in this assay, from the lowest: compounds 4, 2, 3 and 1 (each within the scatter of the next).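

In this assay, benzyl in place of 1-(ethoxycarbonyl)ethyl on an oxygen on an aromatic ring gives a 1.3-fold lower number from compound 3 to compound 4 (0.11 log units; within the scatter). Going by these compounds alone, this is the first direct test of an exchange at this oxygen: a chain with two hydrogen-bond acceptors gives way to a six-membered aromatic ring of carbon only, and the step stays within the scatter. No measurement available here bears on why this is so. As far as these compounds go, whether a carboxylic acid in place of the ethyl ester, or a benzyl carrying a nitrile, would move the number beyond the scatter remains open.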